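Cyanosulfanyl Added to a Core of Weak Cytotoxic Activity

A few compounds are considered here, and "the series" means these few. Any claim that something is new, unique, unknown or untested is made for them only; others in the source may bear on it.

Measured compounds:
Compound 1 `Clc1ccc(Cc2nn3cc(-c4ccc(Br)cc4)nc3s2)cc1` — in a functional assay on L1210 cells (Mus musculus) for cytotoxicity, with a stated time of 48 h (a lower number here means a stronger inhibitor, a higher number a weaker inhibitor), compound 1 gives > 250000 nM, a limit of the assay rather than a number.
Compound 2 `Clc1ccc(Cc2nn3cc(-c4ccccc4)nc3s2)cc1` — in this assay compound 2 gives > 250000 nM, also a limit.
Compound 3 `O=[N+]([O-])c1ccc(-c2cn3nc(Cc4ccc(Cl)cc4)sc3n2)cc1` — in this assay compound 3 gives 214000 nM.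

Compound 2 thus sits at the limit of > 250000 nM in this assay, at which 2 of the 3 values shown sit. The steps touching it are a step that the two limits leave unreadable from compound 1 to compound 2 and an at least 1.1-fold lower number from compound 2 to compound 3 (0.06 log units; that floor lies within the scatter); the remaining step is an at least 1.1-fold lower number from compound 1 to compound 3 (0.06 log units; that floor lies within the scatter). Compound 4 `N#CSc1c(-c2ccccc2)nc2sc(Cc3ccc(Cl)cc3)nn12` differs from compound 2 by cyanosulfanyl in place of hydrogen on an aromatic carbon. All three measured steps alter the group on the phenyl ring, none the core itself, so none bears on this change, and no step beyond the scatter is expected in either direction. Compound 4 is therefore estimated at 200000 nM, between 50000 nM and 500000 nM, which is expected to mean an at least 1.2-fold lower number from compound 2 to compound 4 (0.09 log units; that floor lies within the scatter).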

Compound 4, half-maximal inhibitory concentration: 24000 nM
Estimate against measurement, compound 4: 8.3-fold (0.92 log units) above, outside the stated range (below it).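

Where changes on the phenyl ring had shown no step beyond the scatter, cyanosulfanyl in place of hydrogen on the aromatic carbon next to the ring atom that bears a phenyl group gives an at least 10-fold lower number from compound 2 to compound 4 (1.01 log units; beyond the scatter) in this assay. So the core itself, at this position, responds to substitution far more clearly than the phenyl ring did. This size is only a floor because compound 2 stands at a limit of the assay: the limit of > 250000 nM in this assay, at which 2 of the 4 values shown sit.

From the compounds shown here alone, whether an amine or a methylsulfanyl group at this position would do the same stays open. Also open, going by these compounds, is whether cyanosulfanyl would act alike on the bromo and nitro phenyl rings of compound 1 and compound 3.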